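A second tert-butyl ester in a calcium channel series

The source may hold more compounds than are shown below. What is called first, only, known or untested is meant among the compounds shown, and "the series" means these compounds.

Compound 1 `CCc1nc(Cl)c(C2C(C(=O)OC)=C(C)NC(C)=C2C(=O)OC)[nH]1`: 0.596 nM
Compound 2 `CCc1nc(Cl)c(C2C(C(=O)OC)=C(C)NC(C)=C2C(=O)OC(C)(C)C)[nH]1`: 50.8 nM
Compound 3 `CCc1nc(Cl)c(C2C(C(=O)OC)=C(C)NC(C)=C2C(=O)OCc2ccccc2)[nH]1`: 1.75 nM

Of the compounds shown here, three sharing one core have been tested in an assay on ileum for inhibition of Voltage-dependent L-type calcium channel subunit alpha-1C (Cavia porcellus); a lower number here means a stronger inhibitor, a higher number a weaker inhibitor. Compound 2 gives the highest number of the three, and so is the weakest inhibitor in this assay: compound 3 lies a 29-fold lower number from compound 2 to compound 3 (1.46 log units; beyond the scatter), and compound 1 lies an 85-fold higher number from compound 1 to compound 2 (1.93 log units; beyond the scatter) away in the other direction.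

Compound 4 `CCc1nc(Cl)c(C2C(C(=O)OC(C)(C)C)=C(C)NC(C)=C2C(=O)OC(C)(C)C)[nH]1` takes the change already present in compound 2 and repeats it on the remaining ester: tert-butyl in place of methyl on an oxygen next to a carbonyl group. Among the measured compounds shown here, the one measured step that bears on this is the first such exchange, an 85-fold higher number from compound 1 to compound 2 (1.93 log units; beyond the scatter), which was large and pointed towards weaker inhibition. The benzyl comparison, a 2.9-fold higher number from compound 1 to compound 3 (0.47 log units; beyond the scatter), is a smaller shift in the same direction. On this basis a further rise in the number, and so weaker inhibition, is expected from compound 2 to compound 4, estimated at a 20-fold higher number from compound 2 to compound 4 (1.29 log units; beyond the scatter), though a second exchange need not match the first in size. Compound 4 is therefore estimated at 1000 nM, with a range from 200 nM to 6000 nM.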

Compound 4, half-maximal inhibitory concentration: 34.2 nM
For compound 4 the middle estimate is 29-fold (1.47 log units) above the measured one, outside the stated range (below it).
By their numbers in this assay, from the lowest: compound 1; then compound 3; then compounds 4 and 2 (each within the scatter of the next).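

In this assay, placing tert-butyl on the remaining ester gives a 1.5-fold lower number from compound 2 to compound 4 (0.17 log units; within the scatter), so compound 2 and compound 4 cannot be told apart. The same exchange gave an 85-fold higher number from compound 1 to compound 2 (1.93 log units; beyond the scatter) when the other ester still carried methyl, so in these compounds the exchange has no fixed size: its result differs with what the other ester holds. Nothing available here explains why the second exchange differs so much from the first.

The compounds shown leave open whether this holds for other groups, such as a benzyl on both esters or a longer chain in place of tert-butyl. They also do not show what a carboxylic acid at either ester would do to the number.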